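The compounds below may be only part of what the source reports. "The series", "measured", "known", "first", "only" and "open" are said of these compounds alone.

For the measured compounds named here, the account opens with compound 1 `O=C(/N=C1\NC2(CCCCO2)CCS1)Nc1ccccc1` and compound 2 `O=C(/N=C1\NCCCS1)c1ccc(F)cc1`, the only compounds measured so far in a functional assay on the whole organism (strain CF-1) with Mus musculus as the target, in the writhing test, with a stated time of 15 min; on this read-out higher numbers stand for an effect only at larger amounts of compound and lower numbers for an effect already at smaller amounts. For compound 1 the result in this assay is a limit of the assay and not a number, > 200 mg/kg. For compound 2 the result in this assay is likewise a limit of the assay, > 100 mg/kg. Going by the values given here, one value sits at the limit of > 100 mg/kg in this assay, at which 1 of the 2 values shown sits, and the other at the limit of > 200 mg/kg in this assay, at which 1 of the 2 values shown sits, so no step of known size exists between any two measured compounds, and where compound 1 stands is known only as a limit. From compound 1 the account moves to compound 3 `CC1(C(=O)/N=C2\NC3(CCCCO3)CCS2)CCCCC1`, which differs by 1-methylcyclohexyl in place of anilino on a carbonyl carbon. Among the compounds with values here, since neither measured compound yields a number in this assay, no measured step can guide the expectation; the writer expects no step beyond the usual scatter, and most likely another limit. Compound 3 is therefore estimated at 200 mg/kg in this assay, with an expected range from 60 mg/kg to 600 mg/kg. That estimate corresponds to an expected step of a number no higher from compound 1 to compound 3 (the limit leaves the size open).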

Compound 3, dose for half-maximal effect: > 200 mg/kg
Compound 3: a limit, no number; the forecaster's own chance of this, stated with the estimate: 70%; the middle value lies on the limit itself.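

In this assay compound 3 gives > 200 mg/kg, a limit of the assay and not a number. Compound 1 also stands at a limit, so no step can be read between compound 1 and compound 3. The compounds shown leave open how anilino and 1-methylcyclohexyl on the carbonyl carbon compare in this assay, and whether either gives a numerical value there.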